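Removing the methylsulfanyl from the benzyl ring of compound 1

The source may report more compounds than this note shows. Statements on the series, on what has been measured and on what is new or still open speak of the compounds shown alone.

Working notes on compound 1 `CSc1ccc(CNc2nc(SC)nc3ncccc23)cc1` and the compounds around it. In an ADME assay on 184B5 cells (Homo sapiens) for cytotoxicity, read by MTT assay, with a stated time of 72 h (on this read-out lower numbers stand for stronger inhibition of growth and higher numbers for weaker inhibition of growth), compound 1 gives 1140 nM, the lowest of the two numbers in hand. Its nearest neighbour, compound 2 `CSc1ccc(CNc2nc([SeH])nc3ccccc23)cc1`, gives 86300 nM in this assay, a gap from compound 1 that lies beyond the usual scatter; compound 2 differs from compound 1 in more than one place, so only the two values themselves can be set side by side. For compound 3 `CCCCCSc1nc(O)c2ccccc2n1` this assay reports no number but a limit, > 100000 nM, which is the limit of > 100000 nM in this assay, at which 1 of the 3 values shown sits.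

The unmeasured compound 4 `CSc1nc(NCc2ccccc2)c2cccnc2n1` keeps the core of compound 1 and its benzylamine arm and differs only in hydrogen in place of methylsulfanyl on an aromatic carbon, in words hydrogen in place of methylsulfanyl on an aromatic carbon. Within the data shown here, no measured pair in this set carries the same change, so the size of the step is open. The expectation is a modest loss, a step at the edge of or somewhat beyond the scatter rather than a large one, with the number for compound 4 lying somewhat higher than that of compound 1 in this assay. Compound 4 is therefore estimated at 2500 nM, within 800 nM to 10000 nM. The step from compound 1 to compound 4 is expected to be a 2.2-fold higher number from compound 1 to compound 4 (0.34 log units; beyond the scatter).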

Compound 4, concentration for total growth inhibition: > 100000 nM
Compound 4 ended at the assay's limit; the forecaster's own chance of this, stated with the estimate: 5%; middle value at least 40-fold (1.60 log units) from the limit.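

Hydrogen in place of methylsulfanyl on an aromatic carbon gives an at least 87-fold higher number from compound 1 to compound 4 (1.94 log units; beyond the scatter) in this assay, the first step in the series that isolates a single change. This position, para to a large group, is therefore not one where the substituent can be removed at little cost: with the core and the benzylamine arm unchanged, the methylsulfanyl alone separates a measurable number from the top of the range. Compound 4 gives > 100000 nM, which is a limit and not a number, so the step has a lower bound but no known size, and compound 4 now shares this ceiling with one other compound: the limit of > 100000 nM in this assay, at which 2 of the 4 values shown sit.

On these data alone, whether a methoxy group, a chlorine atom or a longer chain such as ethylsulfanyl at this position would keep the number close to that of compound 1 remains open, so the sulfur atom and the mere presence of a substituent cannot yet be told apart. Also open, as far as these compounds go, is whether the same change would cost as much on another core, since this single pair covers only the core of compound 1.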